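The source may hold more compounds than are shown below. What is called first, only, known or untested is meant among the compounds shown, and "the series" means these compounds.

Compound 1 `CCOC(=O)c1c(-c2ccc(OC)c(OC)c2)csc1N` has the highest number of the three measured compounds in an assay on isolated protein for inhibition of protein kinase C zeta type (Homo sapiens), with stated times of 1 h and 2.5 min, tested at 30 uM (on this read-out higher numbers stand for more inhibition at the one concentration tested (going by the name of the read-out) and lower numbers for less inhibition), where compound 1 gives 100%. Compound 2 `CCOC(=O)c1c(-c2ccc(OC)c(OC)c2)csc1N(C)C` gives 60% and compound 3 `CCOC(=O)c1c(-c2ccc(OC)c(OC)c2)csc1NC(N)=O` gives 14%. The measured steps were a number 40 percentage points lower from compound 1 to compound 2 (beyond the scatter), a number 86 percentage points lower from compound 1 to compound 3 (beyond the scatter) and a number 46 percentage points lower from compound 2 to compound 3 (beyond the scatter); all three alter the nitrogen on the core of compound 1 and leave the rest of the structure as it is. Compound 4 `COCCOC(=O)c1c(-c2ccc(OC)c(OC)c2)csc1N` differs from compound 1 at another place: methoxy in place of hydrogen on a saturated chain carbon, two bonds along the chain from an oxygen next to a carbonyl group. For the measured compounds named here, none of the measured steps touches this part of the molecule, so the data give no direct guide to the size of the step in this assay. Because compound 1 gives 100% and the change sits away from the nitrogen that carried every measured step, the expectation is a step within the scatter or a modest loss, meaning a number 12 percentage points lower from compound 1 to compound 4 (beyond the scatter). Compound 4 is therefore estimated at 88%, with a range from 60% to 100%.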

Compound 4, a percentage reported as inhibition, at one concentration (the size of the read-out at that concentration, not a potency): 57%
Compound 4: the middle estimate sits 31 percentage points above what was measured; measured number below the stated range.
By their numbers in this assay, from the lowest: compound 3; then compounds 4 and 2 (each within the scatter of the next); then compound 1.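

In this assay, for the compounds shown here, methoxy in place of hydrogen on a saturated chain carbon, two bonds along the chain from an oxygen next to a carbonyl group, gives a number 43 percentage points lower from compound 1 to compound 4 (beyond the scatter) and so shows that this read-out responds to the chain as well as to the nitrogen that carried the earlier steps. The change from ethyl to 2-methoxyethyl therefore counts as a large step, as each measured change at that nitrogen does. Nothing given here bears on why the added methoxy lowers the number.

On these data alone, it remains open whether a hydroxy group, an amine or a plain longer chain such as propyl at this place would give a similar number. As far as these compounds go, it is also open whether the same change would have a similar effect on the dimethylamino or ureido compounds.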